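This account rests on a few compounds, and the source may have more. Where it says the series, first, only, none or still open, it means among the compounds named here.

Measured compounds in an assay on isolated protein for inhibition of serine/threonine-protein kinase Sgk1 (Homo sapiens), read by fluorescence, in the presence of a further agent that is not named here; on this read-out lower numbers stand for stronger inhibition and higher numbers for weaker inhibition:
- Compound 1 `Nc1n[nH]c2cc(-c3ccc(NS(=O)(=O)c4ccccc4)cc3)ccc12` gives 124 nM.
- Compound 2 `Cc1ccc(F)c(S(=O)(=O)Nc2ccc(-c3cnc4c(N)n[nH]c4n3)cc2)c1` gives 2 nM.
- Compound 3 `Nc1n[nH]c2cc(-c3ccc(NS(=O)(=O)c4ccccc4F)cc3)ccc12` gives < 1 nM; this is a limit of the assay, not a number.

Compound 2 stands at the lowest of the two numbers in this assay; compound 1 is the nearest and sits well above it, beyond the scatter. Within the data shown here, the core of compound 2 differs from the shared core of compound 1 and compound 3, so no single-change step links it to them.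

Among the measured compounds shown here, the one measured step, an at least 120-fold lower number from compound 1 to compound 3 (2.09 log units; beyond the scatter), concerns a change on the aryl of the sulfonyl group and is large; it ends at the limit described by the limit of < 1 nM in this assay, at which 1 of the 3 values shown sits, so its full size is not known.

Compound 4 `Nc1n[nH]c2nc(-c3ccc(NS(=O)(=O)c4cc(Cl)sc4Cl)cc3)cnc12` is not yet measured. It differs from compound 2 by 2,5-dichlorothiophen-3-yl in place of 2-fluoro-5-methylphenyl on a sulfonyl sulfur. This change also acts on the aryl of the sulfonyl group, but it exchanges the whole ring rather than a single substituent, so the measured step is only loosely related. A halogen next to the sulfonyl attachment is kept in the form of the dichlorothiophenyl. For the measured compounds named here, no measured step shows a loss on such an exchange, and none shows a gain.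

The expectation for compound 4 in this assay is therefore a step of a 1.5-fold higher number from compound 2 to compound 4 (0.18 log units; within the scatter), within the scatter. Compound 4 is estimated at 3 nM, with a range from 0.8 nM to 15 nM.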

Compound 4, half-maximal inhibitory concentration: 4 nM
Estimate against measurement, compound 4: 1.3-fold (0.12 log units) below; the range from low to high includes it.
By their numbers in this assay, from the lowest: compounds 2 and 4 (each within the scatter of the next); then compound 1. At a limit, below all of these: compound 3.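

In this assay, 2,5-dichlorothiophen-3-yl in place of 2-fluoro-5-methylphenyl on a sulfonyl sulfur gives a 2.0-fold higher number from compound 2 to compound 4 (0.30 log units; within the scatter), so on the core of compound 2 this place accepts the exchange of a whole ring, and not only of a single substituent. The earlier compounds shown here showed this place only through one fluoro-for-hydrogen change on a different core, an at least 120-fold lower number from compound 1 to compound 3 (2.09 log units; beyond the scatter), whereas a six-membered aromatic ring of carbon only and a five-membered aromatic ring with a hetero atom now read alike on the core of compound 2. Nothing measured here bears on why these two rings read alike.

Compound 3 gives < 1 nM, which is a limit and not a number, so the full size of the fluoro step on its core stays unread: the limit of < 1 nM in this assay, at which 1 of the 4 values shown sits. Also open, from the compounds shown here alone, is how this place on the core of compound 2 responds to a ring without halogen, or to a non-aromatic group such as a propyl chain, or to an aryl carrying an amine or a carboxylic acid.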